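Para substituent: heptyl chain replaced by phenyl ring

This account rests on a few compounds, and the source may have more. Where it says the series, first, only, none or still open, it means among the compounds named here.

Compound 2 `CCCCCCCc1ccc(-c2c(C)[nH]c(=O)n2C)cc1` stands at the highest of the two numbers measured in a functional assay on the whole organism with Rattus norvegicus as the target (a higher number here means that more compound is needed for the effect, a lower number that less compound is needed), where compound 2 gives 30 mg/kg. Compound 1 `CCCCc1ccc(-c2c(C)[nH]c(=O)n2C)cc1` gives 0.1 mg/kg. Going by the values given here, the only measured step is a 300-fold higher number from compound 1 to compound 2 (2.48 log units; beyond the scatter), a lengthening of the chain. Compound 3 `Cc1[nH]c(=O)n(C)c1-c1ccc(-c2ccccc2)cc1` carries phenyl in place of heptyl on an aromatic carbon. Among the compounds with values here, no measured step covers a ring in place of a chain, so the direction is uncertain; since the heptyl that compound 2 carries is gone, a move back toward compound 1 is expected. Compound 3 is estimated at 1 mg/kg, between 0.1 mg/kg and 15 mg/kg. That estimate means an expected 30-fold lower number from compound 2 to compound 3 (1.48 log units; beyond the scatter).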

Compound 3, minimum effective dose: 0.3 mg/kg
For compound 3 the middle estimate is 3.3-fold (0.52 log units) above the measured one, and the stated range covers the measured number.
By their numbers in this assay, from the lowest: compound 1; then compound 3; then compound 2.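

In this assay, this aromatic carbon tolerates a ring: phenyl in place of heptyl gives a 100-fold lower number from compound 2 to compound 3 (2.00 log units; beyond the scatter), so the high dose seen with the heptyl chain does not carry over to a group of similar size. Against butyl, phenyl gives a 3.0-fold higher number from compound 1 to compound 3 (0.48 log units; beyond the scatter), a modest step that leaves butyl with the lowest number of the three. No available data explain either step.

Open, as far as these compounds go, are the pentyl and hexyl chains between butyl and heptyl, and whether cyclohexyl, or a phenyl bearing an amine or carboxylic acid, would behave like phenyl.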